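The source may hold more compounds than are shown below. What is called first, only, known or untested is meant among the compounds shown, and "the series" means these compounds.

Compound 3 `CC(C)(C)c1ccc(C(=O)N2CCC3(CC2)C(=O)N(CC(=O)NCCO)CN3c2ccccc2)cc1` stands at the low end of the series: in an assay on HEK293 cells for displacement of a labelled ligand from NPC1-like intracellular cholesterol transporter 1 (Homo sapiens) (on this read-out higher numbers stand for weaker inhibition and lower numbers for stronger inhibition), compound 3 gives 1000 nM, the lowest of the three numbers obtained so far. Compound 1 `CC(C)(C)c1ccc(C(=O)N2CCC3(CC2)C(=O)N(CC(=O)NCCC(=O)O)CN3c2ccccc2)cc1` gives 11400 nM, and compound 2 `CC(C)(C)OC(=O)NCCCNC(=O)CN1CN(c2ccccc2)C2(CCN(C(=O)c3ccc(C(C)(C)C)cc3)CC2)C1=O` gives 4500 nM. Both steps toward compound 3 were beyond the scatter, an 11-fold lower number from compound 1 to compound 3 (1.06 log units; beyond the scatter) and a 4.5-fold lower number from compound 2 to compound 3 (0.65 log units; beyond the scatter), and a 2.5-fold lower number from compound 1 to compound 2 (0.40 log units; beyond the scatter) shows that changing only the end of this side chain moves the number each time. Compound 4 `CC(C)(C)c1ccc(C(=O)N2CCC3(CC2)C(=O)N(CC(=O)NCN)CN3c2ccccc2)cc1` varies the same chain once more: amino in place of hydroxymethyl on a saturated chain carbon bound to an amide-type nitrogen. For the measured compounds named here, none of the measured steps puts an amino at this end, so the earlier results give no direction for it; they only show that the terminus of the chain is sensitive in this assay and that the hydroxy end of compound 3 is the best of the three tried. Compound 4 is therefore expected to give about 1800 nM in this assay, somewhere between 450 nM and 7000 nM, an expected step of a 1.8-fold higher number from compound 3 to compound 4 (0.26 log units; within the scatter) that may well stay within the scatter.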

Compound 4, half-maximal inhibitory concentration: 26500 nM
For compound 4 the middle estimate is 15-fold (1.17 log units) below the measured one; measured number above the stated range.
By their numbers in this assay, from the lowest: compound 3; then compound 2; then compound 1; then compound 4.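

In this assay the end of this side chain can push the number up as well as down: amino in place of hydroxymethyl on a saturated chain carbon bound to an amide-type nitrogen gives a 27-fold higher number from compound 3 to compound 4 (1.42 log units; beyond the scatter), the largest step among the compounds shown. The amino end also stands apart from the other two chain ends, with a 5.9-fold higher number from compound 2 to compound 4 (0.77 log units; beyond the scatter) and a 2.3-fold higher number from compound 1 to compound 4 (0.37 log units; beyond the scatter), so the highest number now belongs to this end rather than to the carboxy end. The data shown offer nothing that accounts for this rise.

This change alters the chain length and the terminal atom together, and the compounds shown do not separate the two. On these data alone, how a 2-aminoethyl end, which keeps the chain length of the 2-hydroxyethyl group, or a longer 3-hydroxypropyl chain would read remains open.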